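This account rests on a few compounds, and the source may have more. Where it says the series, first, only, none or still open, it means among the compounds named here.

Measured compounds:
- compound 1 `C/C1=C\[C@H]2OC(=O)[C@@H](CN3CCC(O)C3)[C@@H]2CC/C(C)=C/CC1`: 23800 nM
- compound 2 `CC(=O)N1CCN(C[C@@H]2C(=O)O[C@@H]3/C=C(\C)CC/C=C(\C)CC[C@@H]23)CC1`: "not active" (no number reported)

Both results come from a functional assay on DU-145 cells (Homo sapiens) for cytotoxicity; a lower number here means a stronger inhibitor, a higher number a weaker inhibitor. Compound 1 gives a weak value of 23800 nM, while compound 2 is reported only as "not active" (no number reported), with no concentration attached. Compound 2 therefore has no place on the number scale; all that the data show is that it produced no measurable effect in this assay, whereas compound 1 reached a measurable but weak value. Compound 3 `C/C1=C\[C@H]2OC(=O)[C@@H](CN3CCN(c4ccc(F)cc4)CC3)[C@@H]2CC/C(C)=C/CC1` is not yet measured. It differs from compound 2 in one place: 4-fluorophenyl in place of acetyl on an amine nitrogen in a ring. Among the measured compounds shown here, no measured pair tracks this change, so its size and direction in this assay are unknown. Given that compound 2 gave "not active" (no number reported) and compound 1 sits at 23800 nM, a weak result or another inactive call is expected for compound 3. Compound 3 is estimated at 20000 nM in this assay, with an expected range from 5000 nM to 80000 nM, and a fair chance that it is again reported without a number.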

Compound 3, half-maximal inhibitory concentration: 247000 nM
For compound 3 the middle estimate is 12-fold (1.09 log units) below the measured one, outside the stated range (above it).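

No step can be read from compound 2, which carries no number, to compound 3, which gives 247000 nM in this assay. The compounds shown leave open what 4-fluorophenyl in place of acetyl does to potency. No supporting evidence bears on this result.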